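The source may hold more compounds than are shown below. What is called first, only, known or untested is meant among the compounds shown, and "the series" means these compounds.

Compound 1 `CC(=O)Nc1cccc(-c2ccc(C(=O)N(Cc3cccc(OCCCCCC(=O)O)c3)C(C)C)cc2)c1`: in an ADME assay on HEK293 cells (Homo sapiens) for cytotoxicity, read by CellTiter-Glo and resazurin assay, with a stated time of 72 h (on this read-out lower numbers stand for an effect already at smaller amounts and higher numbers for an effect only at larger amounts of compound), compound 1 gives only a limit, > 26000 nM.
Compound 2 `CC(=O)c1cccc(-c2ccc(C(=O)N(Cc3cccc(OCCCCCC(=O)O)c3)C(C)C)cc2)c1`: in this assay compound 2 gives only a limit, > 26000 nM.
Compound 3 `CC(C)N(Cc1cccc(OCCCCCC(=O)O)c1)C(=O)c1ccc(-c2ccc3[nH]ccc3c2)cc1`: in this assay compound 3 gives only a limit, > 26000 nM.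

Compound 3 therefore stands at the ceiling shared by all three measured compounds, (the limit of > 26000 nM in this assay, at which 3 of the 3 values shown sit). The steps leading to it, a step that the two limits leave unreadable from compound 1 to compound 3 and a step that the two limits leave unreadable from compound 2 to compound 3, cannot be read, and the same holds for a step that the two limits leave unreadable from compound 1 to compound 2. Compound 4 `COc1cc(OC)cc(-c2ccc(C(=O)N(Cc3cccc(OCCCCCC(=O)O)c3)C(C)C)cc2)c1` carries the change (3,5-dimethoxyphenyl in place of 1H-indol-5-yl on an aromatic carbon). Among the compounds with values here, since no measured step has a readable size, no step beyond the usual scatter can be foreseen in this assay, and the estimated change is a step that the limit leaves unreadable from compound 3 to compound 4. Compound 4 is accordingly expected to sit near 40000 nM, within a range from 15000 nM to 110000 nM, most probably reported once more only as a limit.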

Compound 4, half-maximal effective concentration: > 26000 nM
Compound 4 was reported as a limit; the forecaster's own chance of this, stated with the estimate: 85%; the middle value does not contradict the limit.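

Within the data shown here, no step from compound 1, compound 2 or compound 3 to compound 4 can be read, since this assay gives each of them only as a limit: the limit of > 26000 nM in this assay, at which 4 of the 4 values shown sit. The compounds shown leave open at what concentration any of them affects these cells, and whether swapping these groups changes that concentration at all.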